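Cyano to hydroxy among compounds reported only as limits

The compounds below may be only part of what the source reports. "The series", "measured", "known", "first", "only" and "open" are said of these compounds alone.

In an ADME assay on HepG2 cells (Homo sapiens) for cytotoxicity, read by MTT assay, with a stated time of 72 h (a higher number here means that more compound is tolerated, a lower number that less compound is tolerated), compound 1 (`O=[N+]([O-])c1c(CS(=O)(=O)c2ccccc2)nc2c(-c3ccc(Cl)cc3)cc(Cl)cn12`) gives only a limit, > 3900 nM. Compound 2 (`CCN(CC)c1ccc(-c2cc(Cl)cn3c([N+](=O)[O-])c(CS(=O)(=O)c4ccccc4)nc23)cc1`) also gives only a limit, > 15600 nM. Compound 3 (`N#Cc1ccc(-c2cc(Cl)cn3c([N+](=O)[O-])c(CS(=O)(=O)c4ccccc4)nc23)cc1`) likewise stands at a limit, > 3900 nM, so no number fixes its place.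

Compound 4 (`O=[N+]([O-])c1c(CS(=O)(=O)c2ccccc2)nc2c(-c3ccc(O)cc3)cc(Cl)cn12`) carries hydroxy in place of the cyano of compound 3, turning 4-cyanophenyl into 4-hydroxyphenyl: hydroxy in place of cyano on an aromatic carbon. Within the data shown here, three measured steps concern this same place: a step that the two limits leave unreadable from compound 1 to compound 2, a step that the two limits leave unreadable from compound 1 to compound 3 and a step that the two limits leave unreadable from compound 2 to compound 3. Among the measured compounds shown here, none has a readable size, and no measured compound yet carries hydroxy there. The closest guide is a step that the two limits leave unreadable from compound 2 to compound 3, which gives neither size nor direction.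

The expected change, estimated from limits alone, is a step that the limit leaves unreadable from compound 3 to compound 4. A further limit in this assay is the likeliest report. For compound 4 the estimate is 12000 nM, with an expected range from 3900 nM to 40000 nM.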

Compound 4, half-maximal cytotoxic concentration: > 12500 nM
Compound 4: a limit, no number; the forecaster's own chance of this, stated with the estimate: 75%; middle value at least 1.0-fold (0.01 log units) from the limit.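

In this assay compound 4 gives > 12500 nM, which is again a limit and not a number. The steps to compound 4 from compound 1, compound 2 and compound 3 cannot be read. As far as these compounds go, the half-maximal cytotoxic concentration of each of these four compounds remains open.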